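A few compounds are considered here, and "the series" means these few. Any claim that something is new, unique, unknown or untested is made for them only; others in the source may bear on it.

Working notes on the series. Three compounds have been run in an assay on isolated protein (Mus musculus) for inhibition of IL15-IL15 receptor (Homo sapiens), read by resazurin assay, with stated times of 30 min and 2.5 days; on this read-out higher numbers stand for weaker inhibition and lower numbers for stronger inhibition. Compound 1 `Cn1c(Cc2nn(C)c(=O)c3ccccc23)nnc1SCCCCCCCCCCC(=O)Nc1ccccc1Cl` gives 15000 nM, compound 2 `Cn1c(Cc2nn(C)c(=O)c3ccccc23)nnc1SCCCCCCCCCCC(=O)Nc1ccc(Cl)cc1` gives 20000 nM and compound 3 `CCCCCCCCCCSc1nnc(Cc2nn(C)c(=O)c3ccccc23)n1C` gives 7600 nM. Compound 3 has the lowest of the three numbers; its nearest neighbour is compound 1 and its furthest is compound 2. The steps are a 1.3-fold higher number from compound 1 to compound 2 (0.12 log units; within the scatter), a 2.0-fold lower number from compound 1 to compound 3 (0.30 log units; within the scatter) and a 2.6-fold lower number from compound 2 to compound 3 (0.42 log units; beyond the scatter), so removing the carbamoyl end of the chain gave a lower number in both cases, one within and one just beyond the scatter.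

Compound 4 `Cn1c(Cc2nn(C)c(=O)c3ccccc23)nnc1SCCCCCCCCCCC(=O)Oc1ccc(Cl)cc1Cl` is not yet measured. Against compound 3 the change is (2,4-dichlorophenoxy)carbonyl in place of hydrogen on a saturated chain carbon, ten or more bonds along the chain from a sulfur. The two steps that bear on it are the reverse of the carbamoyl removals, namely the steps from compound 3 back to compound 1 and to compound 2, each a small to modest rise in number. Going by the values given here, the same size of step in this assay is expected here, towards a higher number, though the new group is an ester rather than an amide and no direct precedent for that exists in this set. The step is therefore estimated as a 2.0-fold higher number from compound 3 to compound 4 (0.30 log units; within the scatter), and compound 4 is expected to give 15000 nM, with a range from 6000 nM to 40000 nM.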

Compound 4, half-maximal inhibitory concentration: 8700 nM
Compound 4: the middle estimate sits 1.7-fold (0.24 log units) above what was measured; measured number inside the range.
By their numbers in this assay, from the lowest: compounds 3, 4, 1 and 2 (each within the scatter of the next, the first and the last beyond it).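

In this assay, the (2,4-dichlorophenoxy)carbonyl group, 11 heavy atoms on a saturated chain carbon, gives a number within the scatter of the plain chain end (a 1.1-fold higher number from compound 3 to compound 4 (0.06 log units; within the scatter)), so this position takes a group of this size with no readable change. With 2,4-dichlorophenoxy on the carbonyl carbon, the step from the (4-chlorophenyl)amino compound lies beyond the scatter (a 2.3-fold lower number from compound 2 to compound 4 (0.36 log units; beyond the scatter)), but the step from the (2-chlorophenyl)amino compound stays within it (a 1.7-fold lower number from compound 1 to compound 4 (0.24 log units; within the scatter)), so compound 1 goes against any general gain from ester over amide. No measurement here explains these steps.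

Still open, from the compounds shown here alone, is whether a 4-chlorophenoxycarbonyl group would read like compound 4, which would separate the ester link from the second chlorine. Also open, going by these compounds, is how a carboxylic acid at the chain end or a shorter chain would read.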